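This account rests on a few compounds, and the source may have more. Where it says the series, first, only, none or still open, it means among the compounds named here.

Two compounds built on the same core differ only in one group on the shared scaffold. Compound 1 `CC(C)(C)c1ccc(NC(=O)CCc2cccc3c2B(O)OC3)cc1` carries a tert-butyl group, and in a functional assay on MDA-MB-231 cells (Homo sapiens) for antiproliferative activity, read by MTT assay, with a stated time of 72 h (a higher number here means a weaker inhibitor, a lower number a stronger inhibitor), compound 1 gives 33000 nM. Compound 2 `O=C(CCc1cccc2c1B(O)OC2)Nc1cccc(-c2ccccc2)c1` carries a phenyl ring in that position instead, and in this assay compound 2 gives 220 nM, the lower of the two numbers; the number for compound 1 is far higher, well beyond the usual scatter. Compound 3 `CSc1ccc(-c2cccc(NC(=O)CCc3cccc4c3B(O)OC4)c2)cc1` is compound 2 with a single alteration: methylsulfanyl in place of hydrogen on an aromatic carbon. For the measured compounds named here, no measured pair shows this particular change, so the expectation for compound 3 rests on compound 2 alone and on the small size of the entering group. The expected step is a 1.4-fold lower number from compound 2 to compound 3 (0.14 log units; within the scatter), little or nothing beyond the scatter. Compound 3 is therefore estimated at 160 nM in this assay, with a likely range from 50 nM to 600 nM.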

Compound 3, half-maximal inhibitory concentration: 140 nM
Beside the measured number, compound 3's estimate is 1.1-fold (0.06 log units) above it; low and high end bracket the measured number.
By their numbers in this assay, from the lowest: compounds 3 and 2 (each within the scatter of the next); then compound 1.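

Going from phenyl to 4-(methylsulfanyl)phenyl gives a 1.6-fold lower number from compound 2 to compound 3 (0.20 log units; within the scatter) in this assay, so the two numbers cannot be told apart. This shows that an aromatic carbon para to a large group can carry methylsulfanyl without a measurable loss in this assay, something the comparison of compound 1 and compound 2 could not show, as that pair differs by a much larger exchange of groups. No measurement shown here explains why methylsulfanyl is accepted at this position.

On these data alone, how far this tolerance extends remains open, since a single methylsulfanyl group says nothing about an amine, a carboxylic acid or a longer chain on the same carbon. As far as these compounds go, it is also open whether methylsulfanyl on another carbon of that ring would give a number in the same range.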